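The source may hold more compounds than are shown below. What is called first, only, known or untested is meant among the compounds shown, and "the series" means these compounds.

Measured in an ADME assay on PA-1 cells (Homo sapiens) for cytotoxicity, read by MTT assay, with a stated time of 72 h; a lower number here means a stronger inhibitor, a higher number a weaker inhibitor:
- compound 1 `COc1ccc(C2=C(c3cc(OC)c(OC)c(OC)c3)C(=O)C(OC(C)=O)C2)cc1OC(C)C`: > 100 ug/mL (limit)
- compound 2 `COc1ccc(OC)c(C2=C(c3cc(OC)c(OC)c(OC)c3)C(=O)CC2O[SiH2]C(C)(C)C)c1`: 17 ug/mL
- compound 3 `COc1ccc(C2=C(c3cc(OC)c(OC)c(OC)c3)CC(O)C2=O)cc1[N+](=O)[O-]`: > 100 ug/mL (limit)

Compound 1 stands at > 100 ug/mL, which is a limit of the assay and not a number. Compound 3 also gives a limit. Only compound 2 gives a number. Next in the series is compound 4 `COc1ccc(C2=C(c3cc(OC)c(OC)c(OC)c3)C(=O)C(OC(C)=O)C2)cc1F`, with fluoro in place of isopropoxy on an aromatic carbon, ortho to a methoxy group: fluoro in place of isopropoxy on an aromatic carbon. Going by the values given here, no measured pair gives the size of such a step. The expectation therefore rests on (the limit of > 100 ug/mL in this assay, at which 2 of the 3 values shown sit). In this assay, no step beyond the scatter is expected: an at least 1.2-fold lower number from compound 1 to compound 4 (0.09 log units; that floor lies within the scatter). Compound 4 is estimated at 80 ug/mL, with an expected range of 20 ug/mL to 100 ug/mL.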

Compound 4, half-maximal inhibitory concentration: > 100 ug/mL
Compound 4: a limit, no number; the forecaster's own chance of this, stated with the estimate: 55%; at least 1.2-fold (0.09 log units) between middle value and limit.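

The step from compound 1 to compound 4, fluoro in place of isopropoxy on an aromatic carbon, cannot be read: both values are limits, not numbers. The compounds shown leave open whether this exchange moves the value at all.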